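Swapping the Group on the Sulfur of Compound 1

The compounds below may be only part of what the source reports. "The series", "measured", "known", "first", "only" and "open" are said of these compounds alone.

Of the compounds shown here, three that share a core have been measured in a functional assay on SMMC-7721 cells (Homo sapiens) for inhibition, read by CCK-8 assay, with a stated time of 72 h, tested at 8 uM; a higher number here means more inhibition of growth at the concentration tested, a lower number less inhibition of growth. Compound 1 `Cc1ccc(SCc2ccc(C(=O)Nc3ccccc3N)cc2)cc1` gives 82.7%, the highest of the three numbers. Compound 3 `CC(C)(C)c1ccc(SCc2ccc(C(=O)Nc3ccccc3N)cc2)cc1` gives 46.1%, and compound 2 `Nc1ccccc1NC(=O)/C=C/c1ccc(CSc2cccc3ccccc23)cc1` gives 18.3%, so compound 3 stands nearest to compound 1 and compound 2 furthest from it, both beyond the scatter of repeated measurements.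

Among the compounds with values here, only one step between measured compounds changes a single place: a number 36.6 percentage points lower from compound 1 to compound 3 (beyond the scatter). That step shows that a small alteration on the group carried by the sulfur can move the number a long way.

Compound 4 `Nc1ccccc1NC(=O)c1ccc(CSCCc2ccccc2)cc1` differs from compound 1 in this way: phenethyl in place of 4-methylphenyl on a sulfur. Within the data shown here, no measured pair tests exactly this swap, so the expectation rests on the one step that does alter the group on the sulfur, and that step lowered the number by a large amount. A drop in this assay is therefore expected, probably beyond the scatter but smaller than the fall seen for compound 3, since the expected step is a number 24.7 percentage points lower from compound 1 to compound 4 (beyond the scatter). Compound 4 is estimated at 58%, with a range from 30% to 82%.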

Compound 4, percent growth inhibition at one concentration: 77.9%
Compound 4: the middle estimate sits 19.9 percentage points below what was measured; measured number inside the range.
By their numbers in this assay, from the lowest: compound 2; then compound 3; then compounds 4 and 1 (each within the scatter of the next).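

Replacing 4-methylphenyl on a sulfur with phenethyl gives, in this assay, a number 4.8 percentage points lower from compound 1 to compound 4 (within the scatter) and so leaves the two compounds indistinguishable at this one tested concentration. The group on the sulfur can therefore be changed substantially without a clear loss: phenethyl has 8 heavy atoms against 7 and keeps one six-membered aromatic ring of carbon only, and it does not repeat the large fall seen in the step with a number 36.6 percentage points lower from compound 1 to compound 3 (beyond the scatter), where tert-butyl takes the place of methyl on an aromatic carbon. Nothing shown here explains why one change leaves the number in place while the other lowers it so far.

Two compounds that read alike at a single concentration might still separate at lower concentrations, so the equal standing of compound 1 and compound 4 holds only for the conditions tested. Going by these compounds, it also remains open how the number responds to a longer chain such as 3-phenylpropyl on the sulfur, or to an amine or a carboxylic acid carried on the aromatic ring of phenethyl.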